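This account rests on a few compounds, and the source may have more. Where it says the series, first, only, none or still open, it means among the compounds named here.

Compound 1 `CSc1ccc(CNc2nc(SC)nc3ncccc23)cc1`, compound 2 `COc1ccc(CNc2nc(SC)nc3ncccc23)cc1` and compound 3 `COc1ccc(CNc2nc(SC)nc3ccccc23)cc1` have been run in a functional assay on CCRF-CEM cells (Homo sapiens) for cytotoxicity, read by MTT assay, with a stated time of 72 h; on this read-out higher numbers stand for lower toxicity in this test and lower numbers for higher toxicity in this test. In this assay compound 1 gives 59000 nM. For compound 2 this assay returns only a limit, > 100000 nM, and not a number. For compound 3 this assay likewise returns only a limit, > 100000 nM. Compound 2 and compound 1 differ by methylsulfanyl in place of methoxy on an aromatic carbon, and this change carries an at least 1.6-fold lower number from compound 2 to compound 1 (0.22 log units; that floor lies within the scatter); the size of that step is bounded by the limit of > 100000 nM in this assay, at which 2 of the 3 values shown sit, so only its floor is known. The difference between the core of compound 2 and the core of compound 3 is not broken down here; compound 3 sits at the same limit as compound 2, so the two values show no separation in this assay.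

Compound 4 `CSc1ccc(CNc2nc(SC)nc3ccccc23)cc1` has not yet been measured in this assay. It differs from compound 3 by methylsulfanyl in place of methoxy on an aromatic carbon, which is the same change, at the same place, as that from compound 2 to compound 1. For compound 4 the step from compound 3 is expected to be an at least 1.4-fold lower number from compound 3 to compound 4 (0.15 log units; that floor lies within the scatter); this expectation rests on the measured step of an at least 1.6-fold lower number from compound 2 to compound 1 (0.22 log units; that floor lies within the scatter), whose floor is set by the limit of > 100000 nM in this assay, at which 2 of the 3 values shown sit, and whose true size may be larger, and on compound 3 starting at the limit. Compound 4 is therefore expected to give about 70000 nM in this assay, with a plausible range from 30000 nM to 160000 nM, and a fair chance that this assay again reports only a limit for compound 4.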

Compound 4, concentration lethal to 50% of the cells: > 100000 nM
Compound 4 was reported as a limit; the forecaster's own chance of this, stated with the estimate: 40%; middle value at least 1.4-fold (0.15 log units) from the limit.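

In this assay compound 4 gives > 100000 nM, which is a limit and not a number. No step from compound 3 to compound 4 can be read, as both values are limits: the limit of > 100000 nM in this assay, at which 3 of the 4 values shown sit.

The compounds shown leave open whether methylsulfanyl in place of methoxy changes the number at all on the core of compound 3, and where the true values of compound 3 and compound 4 lie.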